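This account rests on a few compounds, and the source may have more. Where it says the series, first, only, none or still open, it means among the compounds named here.

Of the compounds shown here, three sharing one core have been tested in a functional assay on SKW3 cells (Homo sapiens) for antiproliferative activity, read by WST assay, with a stated time of 3 days; on this read-out lower numbers stand for stronger inhibition and higher numbers for weaker inhibition. Compound 1 (`[N-]=[N+]=Nc1cc(=O)[nH]c(=O)n1[C@@H]1O[C@H](CO)[C@@H](O)[C@H]1O`) gives > 50000 nM, which is a limit of the assay. Compound 2 (`Nc1cc(=O)[nH]c(=O)n1[C@@H]1O[C@H](CO)[C@@H](O)[C@H]1O`) gives > 50000 nM, also a limit. Among the compounds with values here, compound 3 (`[N-]=[N+]=Nc1c(F)c(=O)[nH]c(=O)n1[C@@H]1O[C@H](CO)[C@@H](O)[C@H]1O`) gives 400 nM, the only true number so far, and the other results stand at the limit of > 50000 nM in this assay, at which 2 of the 3 values shown sit.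

Compound 4 (`O=Cc1c(F)c(=O)[nH]c(=O)n1[C@@H]1O[C@H](CO)[C@@H](O)[C@H]1O`) departs from compound 3 by one change: formyl in place of azido on an aromatic carbon. It carries formyl in place of azido on an aromatic carbon, ortho to a fluoro group.

Within the data shown here, two measured steps bear on this. Replacing azido once before, with amino in place of azido, gave a step that the two limits leave unreadable from compound 1 to compound 2, so it offers no size to carry over. Fluoro in place of hydrogen gave an at least 120-fold lower number from compound 1 to compound 3 (2.09 log units; beyond the scatter), a large step, but azido stayed in place there and the fluoro group stays in compound 4 as well. Among the measured compounds shown here, no measured step involves formyl. For the measured compounds named here, the one number available, compound 3 at 400 nM, belongs to a compound that holds both fluoro and azido, so losing azido is expected to push the number higher, beyond the scatter, though with wide uncertainty. The expected change is a 13-fold higher number from compound 3 to compound 4 (1.10 log units; beyond the scatter). Compound 4 is estimated at 5000 nM, within an expected range of 600 nM to 40000 nM.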

Compound 4, half-maximal inhibitory concentration: 300 nM
The estimate for compound 4 lay 17-fold (1.22 log units) above the measured number, outside the stated range (below it).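

In this assay, formyl in place of azido on this aromatic carbon gave a 1.3-fold lower number from compound 3 to compound 4 (0.12 log units; within the scatter), so with the fluoro group kept in place, the two groups cannot be told apart at this position. Within the data shown here, this is the first readable step at this position, as the earlier replacement of azido by amino, made without the fluoro group, ran between two limits and could not be read; it shows that, at least with the fluoro group present, azido is not needed here for a number of this size, and that formyl, with one heavy atom fewer and one double bond fewer outside aromatic rings, serves equally well on this read-out. Nothing shown here accounts for why the two groups match.

The compounds shown leave open whether an amine, a carboxylic acid or a longer chain, ortho to a fluoro group at this same carbon, would also keep the number at this level. Going by these compounds, it also remains open whether the large effect of the fluoro group seen with azido would recur with formyl, or whether formyl with hydrogen in place of the fluoro group would reach the same level.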